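Ketone to carbinol on the side chain of compound 1

The source may report more compounds than this note shows. Statements on the series, on what has been measured and on what is new or still open speak of the compounds shown alone.

Compound 1 `CCCCCC(=O)c1ccc(CN(CCCCCCC(=O)O)S(C)(=O)=O)cc1` is tested in an assay on HEK293 cells for inhibition of prostaglandin E2 receptor EP4 subtype (Rattus norvegicus); a lower number here means a stronger inhibitor, a higher number a weaker inhibitor; compound 1 gives > 3200 nM, which is a limit of the assay and not a number. Compound 2 `CC(C)(C)c1ccc(CN(Cc2cccc(CCC(=O)O)c2)S(=O)(=O)c2nccs2)cc1` gives > 3200 nM, also a limit. Compound 3 `CC(C)(C)c1ccc(CN(Cc2cccc(CCC(=O)O)c2)S(=O)(=O)c2ccccn2)cc1` gives > 3200 nM, again a limit. The step that the two limits leave unreadable from compound 2 to compound 3 therefore cannot be read, and it concerns the sulfonyl substituent rather than the change at hand. Compound 4 `CCCCCC(O)c1ccc(CN(CCCCCCC(=O)O)S(C)(=O)=O)cc1` differs from compound 1 by 1-hydroxyhexyl in place of pentylcarbonyl on an aromatic carbon. Among the compounds with values here, no measured step bears on this change; the only anchor, (the limit of > 3200 nM in this assay, at which 3 of the 3 values shown sit), fixes where compound 1 sits. Compound 4 is expected to remain near that limit, the step that the limit leaves unreadable from compound 1 to compound 4 being an estimate without a measured anchor. The estimate for compound 4 in this assay is 5000 nM, with a range from 1500 nM to 20000 nM.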

Compound 4, half-maximal inhibitory concentration: > 3200 nM
Compound 4 was reported as a limit; the forecaster's own chance of this, stated with the estimate: 80%; the middle value is on the limit's open side.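

Compound 1 and compound 4 both stand at a limit and not at a number, so no step can be read for 1-hydroxyhexyl in place of pentylcarbonyl: the limit of > 3200 nM in this assay, at which 4 of the 4 values shown sit.

The compounds shown leave open how far each one lies past that limit, and so whether this change has any effect.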